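The source may hold more compounds than are shown below. What is called first, only, known or untested is meant among the compounds shown, and "the series" means these compounds.

Compound 1 `CCc1ccc(-c2nc3c(c(C)nn3-c3ccccc3)c(-c3ccccc3OC(F)(F)F)c2C#N)cc1`: 9900 nM
Compound 2 `CCc1ccc(-c2nc3c(c(C)nn3-c3ccccc3)c(-c3ccc(O)cc3)c2C#N)cc1`: 5700 nM

In a physicochemical assay for solubility, read by spectrophotometry, in phosphate buffer, with a stated time of 18 h, at pH 7.4 (a higher number here means a more soluble compound, a lower number a less soluble compound), compound 2 gives 5700 nM, within the scatter of compound 1. Compound 3 `CCc1ccc(-c2nc3c(c(C)nn3-c3ccccc3)c(-c3ccccc3C(=O)OC)c2C#N)cc1` is next, with 2-(methoxycarbonyl)phenyl in place of 4-hydroxyphenyl on an aromatic carbon. Among the compounds with values here, only one measured step bears on this change: a 1.7-fold lower number from compound 1 to compound 2 (0.24 log units; within the scatter), also an exchange of the aryl group on that aromatic carbon. Compound 1 carries a 2-substituted phenyl there, as compound 3 does. That step stays within the scatter, so no step beyond the scatter is expected in this assay. The expected change is a 1.3-fold higher number from compound 2 to compound 3 (0.12 log units; within the scatter). For compound 3 the estimated value is 7500 nM, with an expected range of 3500 nM to 16000 nM.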

Compound 3, solubility: 17000 nM
Compound 3: middle estimate off by 2.3-fold (0.36 log units), on the low side, outside the stated range (above it).
By their numbers in this assay, from the lowest: compounds 2, 1 and 3 (each within the scatter of the next, the first and the last beyond it).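

In this assay, the aryl exchange on this aromatic carbon now gives a step beyond the scatter, with a 3.0-fold higher number from compound 2 to compound 3 (0.47 log units; beyond the scatter) for 2-(methoxycarbonyl)phenyl in place of 4-hydroxyphenyl. The exchange of trifluoromethoxy for methoxycarbonyl on the phenyl, a 1.7-fold higher number from compound 1 to compound 3 (0.23 log units; within the scatter), stays within the scatter, so these two 2-substituted phenyl compounds cannot be told apart here. Nothing available gives a cause for the larger step.

As far as these compounds go, whether that step follows the substituent itself or its place on the phenyl remains open. Also open, from the compounds shown here alone, is how a phenyl bearing a carboxylic acid or an amine would read.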